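Methyl for methoxy: an expected cytotoxicity step

A few compounds are considered here, and "the series" means these few. Any claim that something is new, unique, unknown or untested is made for them only; others in the source may bear on it.

Measured so far:
compound 1 `O=C(O)c1c(O)cccc1C=Cc1ccc2ccccc2c1`: 71000 nM
compound 2 `COc1cc(O)c(C(=O)O)c(C=Cc2ccc3ccccc3c2)c1`: 79000 nM

In an ADME assay on HepG2 cells (Homo sapiens) for cytotoxicity, read by resazurin assay, with a stated time of 24 h (on this read-out lower numbers stand for higher toxicity in this test and higher numbers for lower toxicity in this test), compound 1 gives 71000 nM and compound 2 gives 79000 nM. For the measured compounds named here, on these two numbers compound 2 cannot be told apart from compound 1: the only measured step, a 1.1-fold higher number from compound 1 to compound 2 (0.05 log units; within the scatter), leaves the pair inside the usual scatter.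

Compound 3 `Cc1cc(O)c(C(=O)O)c(C=Cc2ccc3ccccc3c2)c1` has not yet been measured. It differs from compound 2 by methyl in place of methoxy on an aromatic carbon. Going by the values given here, the one measured step that bears on this exchange is a 1.1-fold higher number from compound 1 to compound 2 (0.05 log units; within the scatter), which also altered a substituent on an aromatic carbon of the shared core and produced nothing beyond the scatter. Among the compounds with values here, with that as the sole precedent, the account expects the exchange of methoxy for methyl to produce no step beyond the scatter in this assay either, in neither direction.

Compound 3 is therefore estimated to give about 75000 nM in this assay, with a likely range from 35000 nM to 160000 nM. The step this estimate implies is expected to be a 1.1-fold lower number from compound 2 to compound 3 (0.02 log units; within the scatter).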

Compound 3, half-maximal cytotoxic concentration: 30000 nM
Compound 3: the middle estimate sits 2.5-fold (0.40 log units) above what was measured, and the stated range ends above it.
By their numbers in this assay, from the lowest: compound 3; then compounds 1 and 2 (each within the scatter of the next).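

Compound 3 shows that this position, on the aromatic carbon para to a carboxy group, is not silent in this assay: methyl in place of methoxy gives a 2.6-fold lower number from compound 2 to compound 3 (0.42 log units; beyond the scatter) and methyl in place of hydrogen gives a 2.4-fold lower number from compound 1 to compound 3 (0.37 log units; beyond the scatter), in both cases towards higher toxicity in this test. Set against a 1.1-fold higher number from compound 1 to compound 2 (0.05 log units; within the scatter), where hydrogen and methoxy could not be told apart, the three compounds do not run in order of group size, since methyl, with fewer heavy atoms than methoxy, does not fall between hydrogen and methoxy but stands apart from both. Nothing at hand gives a measured reason for this separation.

The compounds shown leave open whether an ethyl, a chlorine, a trifluoromethyl or an amine at this position would side with methyl or with the hydrogen and methoxy pair. They also leave open whether the methyl step would persist if the carboxylic acid of the shared core gave way to a methyl ester or an amide.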